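From tert-butoxycarbonyl to formyl on compound 2

This account rests on a few compounds, and the source may have more. Where it says the series, first, only, none or still open, it means among the compounds named here.

Within the data shown here, in a functional assay on PANC-1 cells (Homo sapiens) for inhibition, read by XTT assay, with a stated time of 72 h (a higher number here means a weaker inhibitor, a lower number a stronger inhibitor), compound 2 (`CC(C)(C)OC(=O)N1CCC[C@H]1COCCCCCCCCC/C=C/c1ccc(-c2ccccc2)cc1`) gives 80000 nM, the only actual number among the three compounds measured so far. Compound 1 (`CCCCCCCC/C=C/CCCCCCCCOC[C@@H]1CCCN1C(=O)OC(C)(C)C`) gives > 100000 nM, which is a limit and not a number. Compound 3 (`CC(C)(C)OC(=O)N1CCC[C@H]1COCCCCCCCCC/C=C/c1ccc(Oc2ccccc2)cc1`) gives > 100000 nM, which is also a limit and not a number. The measured picture is therefore thin, with the limit of > 100000 nM in this assay, at which 2 of the 3 values shown sit.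

Compound 4 (`O=CN1CCC[C@H]1COCCCCCCCCC/C=C/c1ccc(-c2ccccc2)cc1`) has not yet been measured. Its structure departs from that of compound 2 as follows: hydrogen in place of tert-butoxy on a carbonyl carbon. In words, hydrogen takes the place of tert-butoxy on a carbonyl carbon, so tert-butoxycarbonyl becomes formyl.

Among the measured compounds shown here, only one measured step is available as a guide: an at least 1.2-fold higher number from compound 2 to compound 3 (0.09 log units; that floor lies within the scatter). That step puts phenoxy in place of phenyl on an aromatic carbon and leaves the carbonyl untouched, so it bears on the new change only indirectly. For the measured compounds named here, no measured step covers a change at this carbonyl, so the expectation stays close to compound 2, with a wide margin. No step beyond the scatter is expected in this assay, and the estimated move is a 1.6-fold lower number from compound 2 to compound 4 (0.20 log units; within the scatter). Compound 4 is expected at 50000 nM, with an estimated range of 12000 nM to 100000 nM.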

Compound 4, half-maximal inhibitory concentration: 56700 nM
Compound 4: middle estimate off by 1.1-fold (0.05 log units), on the low side, within the range that was stated.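

Among these compounds, the first measured change at this carbonyl carbon, hydrogen in place of tert-butoxy, gives in this assay a 1.4-fold lower number from compound 2 to compound 4 (0.15 log units; within the scatter). Losing all 5 heavy atoms of tert-butoxy, so that tert-butoxycarbonyl becomes formyl, therefore produces no readable change in this comparison, and on this pair the carbonyl substituent can shrink to a single hydrogen without a step beyond the scatter. Even so, the pair sits close to the top of the reported scale, and much of the series gives no number at all: the limit of > 100000 nM in this assay, at which 2 of the 4 values shown sit.

Still open, as far as these compounds go, is whether an amine at the amide-type nitrogen in the ring, with the carbonyl gone altogether, or an acetyl group there would give a step beyond the scatter. Also open, from the compounds shown here alone, is whether formyl in place of tert-butoxycarbonyl would read the same way with the other chain ends, those of compound 1 and compound 3, since this one pair carries the phenyl-bearing chain of compound 2 only.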